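Shortening a Chain: From Compound 2 to Compound 3

The compounds below may be only part of what the source reports. "The series", "measured", "known", "first", "only" and "open" are said of these compounds alone.

Two compounds have numbers in an assay on CHO cells for displacement of a labelled ligand from adenosine receptor A1 (Homo sapiens), read by scintillation counting, with a stated time of 3 h; on this read-out lower numbers stand for stronger inhibition and higher numbers for weaker inhibition. Compound 1, `CCn1c(-c2ccccc2)nc2c(NC3CCC3)ncnc21`, gives 6 nM in this assay. Compound 2, `CCCn1c(-c2ccccc2)nc2c(NC3CCOC3)ncnc21`, gives 25 nM, the higher of the two numbers; compound 1 is the nearest to it, and its number lies lower by a gap beyond the usual scatter. Compound 1 and compound 2 differ from each other in more than one place, so their two values alone cannot be read as a single step. Compound 3, `CCn1c(-c2ccccc2)nc2c(NC3CCOC3)ncnc21`, has not been measured. It differs from compound 2 by hydrogen in place of methyl on a saturated chain carbon, two bonds along the chain from an aromatic nitrogen. Among the measured compounds shown here, no single-change step between measured compounds is known here, so the step to compound 3 is expected to be small, most likely toward a somewhat lower number, though it may stay within the scatter. Compound 3 is therefore expected to give about 15 nM in this assay, within a range from 5 nM to 45 nM. This expectation amounts to a step of a 1.7-fold lower number from compound 2 to compound 3 (0.22 log units; within the scatter).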

Compound 3, inhibition constant: 10 nM
For compound 3 the middle estimate is 1.5-fold (0.18 log units) above the measured one; the range from low to high includes it.
By their numbers in this assay, from the lowest: compounds 1 and 3 (each within the scatter of the next); then compound 2.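

With compound 3, the chain position gets its first single-change reading: in this assay, the change from propyl to ethyl gives a 2.5-fold lower number from compound 2 to compound 3 (0.40 log units; beyond the scatter), a modest step but one beyond the scatter. Compound 3 also isolates the other place of difference, where oxolan-3-yl in place of cyclobutyl on a nitrogen on an aromatic ring gives a 1.7-fold higher number from compound 1 to compound 3 (0.22 log units; within the scatter), which stays within the scatter, so with ethyl on the core this swap shows no clear difference. No supporting data here speak to what lies behind the size of either step.

The compounds shown leave open how a longer chain such as butyl, or a shorter one such as methyl, would read at this position. They also leave open whether propyl to ethyl gives a similar step with cyclobutyl on the nitrogen.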